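Notes on the alkynyl sulfonamides: from compound 3 to compound 4

The source may hold more compounds than are shown below. What is called first, only, known or untested is meant among the compounds shown, and "the series" means these compounds.

Compound 1 `CC(=O)Nc1nc(-c2cccc(NS(=O)(=O)c3ccc(Br)cc3)c2)cs1` in a functional assay on A-375 cells (Homo sapiens) for antiproliferative activity, read by trypan blue exclusion, with a stated time of 48 h, tested at 10 uM (on this read-out lower numbers stand for a stronger effect and higher numbers for a weaker effect at the one concentration tested), gives 25.6%.
Compound 2 `CCCCC#Cc1ccc(S(=O)(=O)Nc2cccc(-c3csc(NC(C)=O)n3)c2)cc1` in this assay gives < 1%, which is a limit of the assay.
Compound 3 `CC(=O)Nc1nc(-c2cccc(NS(=O)(=O)c3ccc(C#C[Si](C)(C)C)cc3)c2)cs1` in this assay gives < 1%, again a limit of the assay and not a number.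

Compound 3 therefore stands at the floor of what this assay can report; (the limit of < 1% in this assay, at which 2 of the 3 values shown sit). Compound 4 `C#Cc1ccc(S(=O)(=O)Nc2cccc(-c3csc(NC(C)=O)n3)c2)cc1` differs from compound 3 by a hydrogen atom in place of a group of 4 heavy atoms (3 carbon, 1 silicon; no ring), on a triple-bonded carbon. Going by the values given here, no measured step strips a group from the alkyne. The closest points of reference are a number at least 24.6 percentage points lower from compound 1 to compound 3 (beyond the scatter) and the step that the two limits leave unreadable from compound 2 to compound 3. Both alkynyl compounds sit at the limit, so a terminal alkyne may keep that strength or fall back toward compound 1. Compound 4 is expected to show a number at least 5 percentage points higher from compound 3 to compound 4 (that floor lies within the scatter). Compound 4 is thus estimated at 6%, within 1% to 25%.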

Compound 4, a percentage reported as activity, at one concentration (the size of the read-out at that concentration, not a potency): 1.2%
Estimate against measurement, compound 4: 4.8 percentage points above; the range from low to high includes it.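

In this assay, the unsubstituted ethynyl group alone accounts for the gain over bromo on the aromatic carbon, with a number 24.4 percentage points lower from compound 1 to compound 4 (beyond the scatter). A hydrogen atom in place of the silicon-bearing group gives a number at least 0.2 percentage points higher from compound 3 to compound 4 (that floor lies within the scatter), and hydrogen in place of butyl gives a number at least 0.2 percentage points higher from compound 2 to compound 4 (that floor lies within the scatter). Neither end group on the triple-bonded carbon is therefore needed to keep this level of effect.

No order can be read among compound 2, compound 3 and compound 4, and the step between the two limits cannot be read: the limit of < 1% in this assay, at which 2 of the 4 values shown sit. Going by these compounds, whether an amine or a carboxylic acid on the alkyne would hold this level stays open.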